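A few compounds are considered here, and "the series" means these few. Any claim that something is new, unique, unknown or untested is made for them only; others in the source may bear on it.

Compound 1 `CNC(=O)c1cc(C(=O)NC2CC2)cn(Cc2ccc(F)cc2)c1=O` gives >= 162 ug/mL in a physicochemical assay for solubility; on this read-out lower numbers stand for lower solubility and higher numbers for higher solubility. Compound 2 `CCNC(=O)c1cc(C(=O)NC)c(=O)n(Cc2ccccc2)c1` gives >= 144 ug/mL in this assay.

Both numbers are limits of the assay rather than measured values. Compound 1 stands at the limit of >= 162 ug/mL in this assay, at which 1 of the 2 values shown sits, which is a limit. Compound 2 stands at the limit of >= 144 ug/mL in this assay, at which 1 of the 2 values shown sits, likewise a limit. Among the compounds with values here, no step between measured compounds is therefore available for this assay.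

Compound 3 `CNC(=O)c1cc(C(=O)NC2CC2)cn(Cc2cccc(OC)c2)c1=O` is not yet measured. It differs from compound 1 by 3-methoxyphenyl in place of 4-fluorophenyl on a saturated chain carbon bound to an aromatic nitrogen. Compound 3 is expected to give 160 ug/mL, within 80 ug/mL to 320 ug/mL. The expected step of an at least 1.0-fold lower number from compound 1 to compound 3 (0.00 log units; that floor lies within the scatter) is none beyond the scatter.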

Compound 3, solubility: 79 ug/mL
Compound 3: the middle estimate sits 2.0-fold (0.31 log units) above what was measured; the whole stated range lies above it.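

In this assay the change to 3-methoxyphenyl in place of 4-fluorophenyl on a saturated chain carbon bound to an aromatic nitrogen gives an at least 2.0-fold lower number from compound 1 to compound 3 (0.31 log units; beyond the scatter) and so shows that the read-out responds to this position. Compound 3 is the only compound shown whose value is not a limit. Nothing shown accounts for the step.

From the compounds shown here alone, compound 1 stands at a limit, so the full size of the step stays open. Also open, going by these compounds, is how a group carrying an amine or a carboxylic acid would read at this position.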